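Swapping methoxy for chloro on an oxime series

The source may report more compounds than this note shows. Statements on the series, on what has been measured and on what is new or still open speak of the compounds shown alone.

Three oximes have been measured in a functional assay (Mus musculus, strain Balb/c) for inhibition, read by ELISA, with a stated time of 72 h; a lower number here means a stronger inhibitor, a higher number a weaker inhibitor. Compound 1 `COc1ccc(C(/C=C/c2ccc(Cl)cc2)=N/O)cc1` gives 11500 nM. Compound 2 `COc1ccc(C(/C=C/c2cccs2)=N/O)cc1` gives 8490 nM. Compound 3 `O/N=C(\C=C\c1ccc(Cl)cc1)c1ccc(Cl)cc1` gives 9150 nM. All three numbers lie within the usual scatter of one another, so none of the three can be called stronger or weaker than the others on this evidence.

Compound 1 and compound 3 differ in one place: chloro in place of methoxy on an aromatic carbon. This change gave a 1.3-fold lower number from compound 1 to compound 3 (0.10 log units; within the scatter), a step too small to count as a real gain. How compound 2 differs from compound 1 is not broken down here; the two cores are different, and only their two values can be compared, which sit close together.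

Compound 4 `O/N=C(\C=C\c1cccs1)c1ccc(Cl)cc1` has not yet been measured. It stands to compound 2 as compound 3 stands to compound 1, and the change is the same: chloro in place of methoxy on an aromatic carbon. The place of the change is described in the same words for both pairs, so the same kind of step can be expected. Because the first such swap gave a 1.3-fold lower number from compound 1 to compound 3 (0.10 log units; within the scatter), compound 4 is expected to give a value near that of compound 2, shifted by about a 1.2-fold lower number from compound 2 to compound 4 (0.08 log units; within the scatter). Compound 4 is therefore estimated at 7000 nM, with a likely range from 3500 nM to 14000 nM.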

Compound 4, half-maximal inhibitory concentration: 9590 nM
The estimate for compound 4 lay 1.4-fold (0.14 log units) below the measured number; measured number inside the range.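

In this assay, putting chloro in place of methoxy on an aromatic carbon of the second core gave a 1.1-fold higher number from compound 2 to compound 4 (0.05 log units; within the scatter), a step too small to tell apart from no change at all. Set beside the same swap on the core of compound 1, the new step agrees with the earlier one as far as these measurements can tell: the same change on two cores in this assay, a 1.3-fold lower number (0.10 log units; within the scatter) from compound 1 to compound 3 and a 1.1-fold higher number (0.05 log units; within the scatter) from compound 2 to compound 4, 1.4-fold (0.15 log units) apart, within the scatter of two such steps This shows that on both cores, the swap leaves the number within the usual scatter of repeated measurements, so the modest result carried over from one core to the other; it does not show that the swap has a real effect on either core, it gives no direction for such an effect, and it cannot say how the swap would behave on any core beyond these two.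

The compounds shown hold only methoxy or chloro at this place, so it remains open whether an amine, a carboxylic acid or a longer chain there would move the number beyond the scatter. All four compounds also keep the oxime, which leaves open what would happen to the number if a carboxylic acid or an amide stood in its place.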